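The source may report more compounds than this note shows. Statements on the series, on what has been measured and on what is new or still open speak of the compounds shown alone.

Working notes on the series in an ADME assay on THP-1 cells (Homo sapiens) for cytotoxicity, read by MTT assay, with a stated time of 72 h; on this read-out higher numbers stand for an effect only at larger amounts of compound and lower numbers for an effect already at smaller amounts.

Compound 1 `Cc1cncc(-c2ccc3[nH]c(=O)nc(-c4ccccc4)c3c2)c1` is the reference point here. In this assay compound 1 gives > 50000 nM, which is a limit of the assay and not a number. Compound 2 `CN(C)c1ccc(-c2ccc3[nH]c(=O)nc(-c4ccccc4)c3c2)cn1` gives > 50000 nM in this assay, again a limit. Compound 3 `O=c1nc(-c2ccccc2)c2cc(-c3ccc(N4CCCC4)nc3)ccc2[nH]1` gives > 50000 nM in this assay, also a limit. Every value shown so far sits at the same place, (the limit of > 50000 nM in this assay, at which 3 of the 3 values shown sit), so compound 1 stands exactly where the others stand and nothing separates any of them. Going by the values given here, the only step measured between neighbours, a step that the two limits leave unreadable from compound 2 to compound 3, cannot be read for the same reason.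

The next compound, compound 4 `Cn1cc(-c2ccc3[nH]c(=O)nc(-c4ccccc4)c3c2)cn1`, differs from compound 1 by 1-methyl-1H-pyrazol-4-yl in place of 5-methylpyridin-3-yl on an aromatic carbon. Among the compounds with values here, no measured step bears on this change. Given that compound 1 gives > 50000 nM and the other measured values are likewise limits, the expected outcome for compound 4 in this assay is again a limit at the same point. Compound 4 is therefore estimated at 50000 nM, with a range from 25000 nM to 100000 nM. The step this estimate means, a number no higher from compound 1 to compound 4 (the limit leaves the size open), is expected to be none beyond the scatter.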

Compound 4, half-maximal effective concentration: > 50000 nM
Compound 4 ended at the assay's limit (the forecaster's own chance of this, stated with the estimate: 85%); the middle value lies on the limit itself.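

No step can be read from compound 1 to compound 4, as both values in this assay are limits: the limit of > 50000 nM in this assay, at which 4 of the 4 values shown sit.

The compounds shown leave open whether any of these groups changes the read-out in this assay, and at what concentration, if any, an effect would appear.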